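From 2-chlorophenyl to 4-chlorophenyl: compound 2 and compound 4

The source may hold more compounds than are shown below. What is called first, only, known or untested is meant among the compounds shown, and "the series" means these compounds.

Measured in a toxicity assay on J774.A1 cells (Mus musculus) for cytotoxicity, read by SYBR Green assay, with a stated time of 1 h; on this read-out lower numbers stand for an effect already at smaller amounts and higher numbers for an effect only at larger amounts of compound:
compound 1 `CN(C)c1ccc2cc(-c3ccccc3)c(N)nc2c1`: 4900 nM
compound 2 `CN(C)c1ccc2cc(-c3ccccc3Cl)c(N)nc2c1`: 2400 nM
compound 3 `COc1ccccc1-c1cc2ccc(N(C)C)cc2nc1N`: 4800 nM

Two steps fix the standing of compound 2 in this assay: a 2.0-fold lower number from compound 1 to compound 2 (0.31 log units; beyond the scatter), and a 2.0-fold higher number from compound 2 to compound 3 (0.30 log units; within the scatter). Compound 4 `CN(C)c1ccc2cc(-c3ccc(Cl)cc3)c(N)nc2c1` has not yet been measured. Its structure differs from that of compound 2 as follows: 4-chlorophenyl in place of 2-chlorophenyl on an aromatic carbon. This places 4-chlorophenyl in place of 2-chlorophenyl on an aromatic carbon, so the atoms stay the same and only their joining changes. Going by the values given here, no measured step moves a group in this way, so the evidence is indirect. Adding the chloro gave a 2.0-fold lower number from compound 1 to compound 2 (0.31 log units; beyond the scatter), a modest step, while adding the methoxy gave a 1.0-fold lower number from compound 1 to compound 3 (0.01 log units; within the scatter). With steps this small, nothing beyond the scatter is expected here. The expected change is a 1.4-fold higher number from compound 2 to compound 4 (0.15 log units; within the scatter). For compound 4 the estimated value in this assay is 3400 nM, with an expected range of 1600 nM to 6500 nM.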

Compound 4, half-maximal effective concentration: 2900 nM
The estimate for compound 4 lay 1.2-fold (0.07 log units) above the measured number, and the stated range covers the measured number.
By their numbers in this assay, from the lowest: compounds 2, 4, 3 and 1 (each within the scatter of the next, the first and the last beyond it).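

In this assay, going by these compounds alone, taking the chloro from 2-chlorophenyl to 4-chlorophenyl gives a 1.2-fold higher number from compound 2 to compound 4 (0.08 log units; within the scatter), so on this read-out the two placements on the phenyl ring cannot be told apart, something the earlier compounds could not show. Set against the compound without any substituent on the phenyl ring, the 4-chlorophenyl group gives a 1.7-fold lower number from compound 1 to compound 4 (0.23 log units; within the scatter), while the 2-chlorophenyl group gave a 2.0-fold lower number from compound 1 to compound 2 (0.31 log units; beyond the scatter), so only the latter step lies beyond the scatter, and narrowly. Nothing measured here accounts for these numbers.

The compounds shown leave open whether the flat response at this position holds for groups other than chloro and methoxy on the phenyl ring. An amine or a carboxylic acid in that place could still shift the number in either direction.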